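Shortening the Selenium-Bearing Group of Compound 2

This account rests on a few compounds, and the source may have more. Where it says the series, first, only, none or still open, it means among the compounds named here.

Among the compounds with values here, only two compounds have numbers so far. In a functional assay on MDA-MB-231 cells (Homo sapiens) for inhibition, read by MTT assay, with a stated time of 48 h (on this read-out higher numbers stand for weaker inhibition and lower numbers for stronger inhibition), compound 2 (`COc1ccc(N(C)c2nc(C)nc3ccccc23)cc1C(=O)NCC[Se]C#N`) gives 1250 nM, the higher of the two values and so the weaker inhibitor. Compound 1 (`C[Se]c1ccc(N(C)c2nc(C3CC3)nc3ccccc23)cc1`) gives 18 nM, a gap well beyond the usual scatter of repeated measurements.

Compound 3 (`COc1ccc(N(C)c2nc(C)nc3ccccc23)cc1[Se]C#N`) keeps the core of compound 2 and changes one group: a group of 3 heavy atoms (1 carbon, 1 nitrogen, 1 selenium; no ring) in place of a group of 8 heavy atoms (4 carbon, 2 nitrogen, 1 oxygen, 1 selenium; no ring), on an aromatic carbon. The new group sits on an aromatic carbon, ortho to a methoxy group and meta to a large group.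

Within the data shown here, no measured pair shows this change on its own, so any forecast is rough. Among the measured compounds shown here, the only guide is compound 1, which also has selenium on an aromatic carbon and gives 18 nM, although it differs from compound 3 in other places as well. A moderate move toward stronger inhibition therefore seems likely in this assay, and the estimated change is a step of a 6.3-fold lower number from compound 2 to compound 3 (0.80 log units; beyond the scatter). For compound 3, the expected value is 200 nM, with an estimated range from 30 nM to 1500 nM.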

Compound 3, half-maximal inhibitory concentration: 52 nM
Estimate against measurement, compound 3: 3.8-fold (0.59 log units) above; low and high end bracket the measured number.
By their numbers in this assay, from the lowest: compound 1; then compound 3; then compound 2.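

In this assay, putting the group of 3 heavy atoms in place of the group of 8 heavy atoms on the aromatic carbon gives a 24-fold lower number from compound 2 to compound 3 (1.38 log units; beyond the scatter), a large step that shows inhibition at this position depends strongly on what is attached there. Within this pair, the selenium and nitrile do not need the longer amide-bearing chain: joined directly to the aromatic carbon, ortho to a methoxy group, they go with the stronger inhibition. Nothing measured here explains why the step is so large.

It remains open which part of the departing group accounts for the step, as the carbonyl, the amide hydrogen and the chain all leave together in this single change. The role of selenium is also unresolved, and a nitrile on the same aromatic carbon without selenium, or a simple amine there, would help to show whether the selenium-bearing group itself is needed or whether a small group in this place is enough.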